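From fluoro to methoxy: the step to compound 4

The source may hold more compounds than are shown below. What is called first, only, known or untested is meant among the compounds shown, and "the series" means these compounds.

Of the compounds shown here, three have been measured so far in a physicochemical assay for solubility, in phosphate buffer, measured as kinetic solubility, at pH 7.4; a higher number here means a more soluble compound, a lower number a less soluble compound.

- Compound 1 `COc1ccc(-c2cc([C@@H](O)C[C@@H](O)CCc3ccc(Cl)cc3)no2)cc1` gives 12000 nM
- Compound 2 `COc1ccc(CC[C@H](O)C[C@H](O)c2cc(-c3ccc(OC)cc3)on2)cc1` gives 12000 nM
- Compound 3 `O[C@@H](CCc1ccc(F)cc1)C[C@@H](O)c1cc(-c2ccccc2)on1` gives 25000 nM

Compound 3 stands highest of the three, and its gap to each of the other two lies beyond the scatter. It differs from both in more than one place, so that gap cannot be assigned to any single group.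

Compound 4 `COc1ccc(CC[C@H](O)C[C@@H](O)c2cc(-c3ccccc3)on2)cc1` is reached from compound 3 by one change, (methoxy in place of fluoro on an aromatic carbon). This is methoxy in place of fluoro on an aromatic carbon, para to a large group, or 4-fluorophenyl to 4-methoxyphenyl.

Going by the values given here, one measured step bears on it: no change at the digits printed from compound 1 to compound 2 (within the scatter), with methoxy in place of chloro on an aromatic carbon. Among the compounds with values here, the group entering is the same, but the group leaving is not, and no measured step has fluoro leaving. That step is therefore a near guide and not a direct one. It gives no reason to expect a shift in either direction in this assay beyond the scatter.

The expected change is a 1.1-fold lower number from compound 3 to compound 4 (0.04 log units; within the scatter), small and within the scatter. For compound 4 the estimated value is 23000 nM, with an expected range from 11000 nM to 45000 nM.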

Compound 4, solubility: 25000 nM
The estimate for compound 4 lay 1.1-fold (0.04 log units) below the measured number; the range from low to high includes it.
By their numbers in this assay, from the lowest: compounds 1 and 2 (each within the scatter of the next); then compounds 3 and 4 (each within the scatter of the next).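

In this assay, the step with fluoro leaving gives no change at the digits printed from compound 3 to compound 4 (within the scatter), so at this place on the six-membered aromatic ring, para to a large group, 4-fluorophenyl to 4-methoxyphenyl leaves the read-out unchanged within the scatter. Going by these compounds alone, until now, the only step with methoxy entering had chloro leaving: no change at the digits printed from compound 1 to compound 2 (within the scatter). Among the compounds shown, both steps with methoxy entering now agree, none goes against them, and no supporting data are available to explain this flat result.

Both steps replace a halogen with methoxy, so they do not show whether a group of a different kind, such as an amine or a carboxylic acid, would also leave the number in place at this position, or whether a longer chain ending in an ether oxygen would do so. The difference between the values of compounds 1 and 2 and those of compounds 3 and 4 also stays unassigned, since no single-place step shown connects the two pairs.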